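Replacing the ring-nitrogen benzyl group with a thiourea-type substituent

This account rests on a few compounds, and the source may have more. Where it says the series, first, only, none or still open, it means among the compounds named here.

Of the compounds shown here, two have been measured in a functional assay on HL-60 cells (Homo sapiens) for antiproliferative activity, with a stated time of 24 h; a higher number here means a weaker inhibitor, a lower number a stronger inhibitor. Compound 1 `NC(=O)c1c(NC(=O)c2ccccc2Cl)sc2c1CCN(Cc1ccccc1Cl)C2` is the reference point: in this assay compound 1 gives 2900 nM, the lowest of the two numbers in hand. Among the measured compounds shown here, compound 2 `NC(=O)c1c(NC(=O)c2ccc(C(F)(F)F)cc2)sc2c1CCN(Cc1ccc(Cl)cc1Cl)C2` differs from compound 1 in more than one place, so no single step can be drawn between them; in this assay compound 2 gives 14900 nM, a gap from compound 1 that lies beyond the scatter.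

Compound 3 `COc1ccc(NC(=S)N2CCc3c(sc(NC(=O)c4ccccc4Cl)c3C(N)=O)C2)cc1` has not yet been measured. It differs from compound 1 as follows: a group of 11 heavy atoms (8 carbon, 1 nitrogen, 1 oxygen, 1 sulfur; one six-membered aromatic ring of carbon only) in place of a group of 8 heavy atoms (7 carbon, 1 chlorine; one six-membered aromatic ring of carbon only), on an amine nitrogen in a ring. The amide on the thiophene ring and the carboxamide of the shared core are kept, so the change is confined to the substituent on the ring nitrogen.

For the measured compounds named here, no measured step of this kind exists, so the expectation rests on compound 1 alone. The step from compound 1 to compound 3 is expected to be small, at most a mild weakening, a 1.6-fold higher number from compound 1 to compound 3 (0.19 log units; within the scatter). In this assay compound 3 is expected to give about 4500 nM, within a range of 1200 nM to 17000 nM.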

Compound 3, half-maximal inhibitory concentration: 15700 nM
The estimate for compound 3 lay 3.5-fold (0.54 log units) below the measured number, within the range that was stated.
By their numbers in this assay, from the lowest: compound 1; then compounds 2 and 3 (each within the scatter of the next).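

Among the compounds shown here, this is the first step confined to one place, and it shows that the substituent on the amine nitrogen in the ring matters in this assay: replacing 2-chlorobenzyl with the thiourea-type group gives a 5.4-fold higher number from compound 1 to compound 3 (0.73 log units; beyond the scatter), with the rest of the shared core kept. The entering group retains one six-membered aromatic ring of carbon only, so an aromatic ring in the substituent is not enough on its own to keep the number of compound 1; it also brings 1 hydrogen-bond donor and 2 hydrogen-bond acceptors, where 2-chlorobenzyl has none. No measurement available here accounts for this step.

The compounds shown leave open whether the weakening belongs to the sulfur-bearing link or to the aromatic ring it carries, and a urea on the same ring, with oxygen in place of the sulfur, would separate the two. Also open, from the compounds shown here alone, is how a plain benzyl group or a short alkyl chain on the ring nitrogen would compare with compound 1, which would show whether the chlorine of 2-chlorobenzyl contributes to its number.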